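The source may report more compounds than this note shows. Statements on the series, on what has been measured and on what is new or still open speak of the compounds shown alone.

Among the measured compounds shown here, in a functional assay on HepG2 cells (Homo sapiens) for inhibition, read by MTT assay, with a stated time of 72 h (on this read-out lower numbers stand for stronger inhibition and higher numbers for weaker inhibition), compound 1 (`Cc1noc(C)c1-c1cnc(N)c(Oc2ccc(C(=O)NC3CC3)cc2)n1`) gives 43200 nM, the only actual number available so far. Compound 2 (`Cc1noc(C)c1-c1cnc(N)c(Oc2ccc(C(=O)Nc3ccccc3Cl)cc2)n1`) reads > 100000 nM, which is a limit of the assay and not a number. Compound 3 (`Cc1noc(C)c1-c1cnc(N)c(Oc2ccc(C(=O)Nc3cccc(Cl)n3)cc2)n1`) has not yet been measured, and it differs from compound 1 on an amide-type nitrogen: 6-chloropyridin-2-yl in place of cyclopropyl on an amide-type nitrogen. For the measured compounds named here, the one measured step that bears on this change is an at least 2.3-fold higher number from compound 1 to compound 2 (0.36 log units; beyond the scatter), where 2-chlorophenyl takes the place of cyclopropyl on that same nitrogen. Taking an at least 2.3-fold higher number from compound 1 to compound 2 (0.36 log units; beyond the scatter) as the guide, a modest move toward weaker inhibition is expected in this assay, not a large one. The expected size of the change is a 2.1-fold higher number from compound 1 to compound 3 (0.32 log units; beyond the scatter). In this assay, the estimated value for compound 3 is 90000 nM, with an expected range of 35000 nM to 200000 nM.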

Compound 3, half-maximal inhibitory concentration: 35700 nM
The estimate for compound 3 lay 2.5-fold (0.40 log units) above the measured number; measured number inside the range.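

In this assay, an aromatic ring on the amide-type nitrogen does not of itself shift the read-out: 6-chloropyridin-2-yl in place of cyclopropyl gives a 1.2-fold lower number from compound 1 to compound 3 (0.08 log units; within the scatter). Compound 2 shows that this does not hold for every aromatic group, since 6-chloropyridin-2-yl in place of 2-chlorophenyl gives an at least 2.8-fold lower number from compound 2 to compound 3 (0.44 log units; beyond the scatter), so the identity of the ring counts at this position. The true size of that second step remains unknown because compound 2 stands at a limit of the assay, not at a number: the limit of > 100000 nM in this assay, at which 1 of the 3 values shown sits.

The compounds shown include neither a plain phenyl nor a plain pyridin-2-yl on this nitrogen, which leaves the ring nitrogen and the place of the chlorine unseparated. As far as these compounds go, how a longer alkyl chain or a carboxylic acid-bearing group would read here also remains open.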